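The source may hold more compounds than are shown below. What is called first, only, known or untested is meant among the compounds shown, and "the series" means these compounds.

Measured in a functional assay on NCI/ADR-RES cells (Homo sapiens) for inhibition, read by sulforhodamine B assay, with a stated time of 48 h; on this read-out higher numbers stand for weaker inhibition of growth and lower numbers for stronger inhibition of growth:
- Compound 1 `S=C(N/N=C/c1cccs1)Nc1ccccc1`: > 100000 nM, a limit
- Compound 2 `CCc1ccc(NC(=S)N/N=C/c2cccs2)cc1`: > 100000 nM, a limit

Compound 2 has no number, only the limit > 100000 nM. Among the compounds with values here, the one other measured compound gives no number either: the limit of > 100000 nM in this assay, at which 2 of the 2 values shown sit. Within the data shown here, the only measured step is a step that the two limits leave unreadable from compound 1 to compound 2, so it offers no size to carry forward. Compound 3 `S=C(N/N=C/c1cccs1)Nc1ccc(Br)cc1` has bromo in place of ethyl on an aromatic carbon, para to a large group: bromo in place of ethyl on an aromatic carbon. With no readable step as a guide, no change beyond the scatter is expected in this assay, and the expected step is a number no higher from compound 2 to compound 3 (the limit leaves the size open). For compound 3 the estimate is 100000 nM, with an expected range from 30000 nM to 150000 nM.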

Compound 3, concentration for 50% growth inhibition: 1700 nM
The estimate for compound 3 lay 59-fold (1.77 log units) above the measured number, and the stated range ends above it.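

In this assay, this position on the aromatic carbon, para to a large group, turns out to respond strongly to the group it carries: bromo in place of ethyl gives an at least 58-fold lower number from compound 2 to compound 3 (1.76 log units; beyond the scatter), and bromo in place of hydrogen gives an at least 58-fold lower number from compound 1 to compound 3 (1.76 log units; beyond the scatter). Only bromo yields a number here, whereas ethyl and hydrogen yield limits, so both steps give a smallest size and not an exact one: the limit of > 100000 nM in this assay, at which 2 of the 3 values shown sit.

The compounds shown leave open whether chloro or fluoro at this place would match bromo. They also leave open how a methoxy group or a nitrile would fare there.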